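A few compounds are considered here, and "the series" means these few. Any claim that something is new, unique, unknown or untested is made for them only; others in the source may bear on it.

Series notes. The compounds share one core carrying an amide; compound 1 is `COc1cccc(C(=O)Nc2cc(Sc3ncn[nH]3)c(O)c3ccccc23)c1`. In a functional assay on PC-3 cells (Homo sapiens) for antiproliferative activity, read by MTT assay, with a stated time of 48 h (a higher number here means a weaker inhibitor, a lower number a stronger inhibitor), compound 1 gives 42100 nM. Compound 2 is `O=C(/C=C/c1ccc([N+](=O)[O-])cc1)Nc1cc(Sc2ncn[nH]2)c(O)c2ccccc12`. In this assay compound 2 reaches only a limit of the assay, > 100000 nM. Compound 3 is `O=C(Nc1cc(Sc2ncnc3nc[nH]c23)c(O)c2ccccc12)c1ccc([N+](=O)[O-])cc1`. For compound 3 this assay likewise returns only a limit, > 100000 nM. Compound 1 thus stands as the only one of the three with a number rather than a limit; the other two sit at the limit of > 100000 nM in this assay, at which 2 of the 3 values shown sit. Within the data shown here, no pair among the measured compounds differs in a single place, so no measured step is available to calibrate the exchange considered next.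

Compound 4 is `Cc1cccc(C(=O)Nc2cc(Sc3ncn[nH]3)c(O)c3ccccc23)c1`. It differs from compound 1 by methyl in place of methoxy on an aromatic carbon. Nothing measured in this set speaks to such an exchange. The expectation for the step in this assay is therefore no change beyond the usual scatter, in either direction: the estimated step is a 1.1-fold higher number from compound 1 to compound 4 (0.03 log units; within the scatter). Compound 4 is accordingly expected to give about 45000 nM, with an estimated range from 15000 nM to 140000 nM, and a fair chance that the assay returns only a limit.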

Compound 4, half-maximal inhibitory concentration: 59500 nM
Compound 4: middle estimate off by 1.3-fold (0.12 log units), on the low side; measured number inside the range.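

In this assay, among these compounds, the exchange gives the first measured step, a 1.4-fold higher number from compound 1 to compound 4 (0.15 log units; within the scatter), so 3-methoxyphenyl to 3-methylphenyl does not move the read-out beyond the scatter. At this place on the aromatic ring, the leaving group's oxygen and its hydrogen-bond acceptor can therefore be replaced by methyl without a change that this assay can separate. Compound 4 also returns a number rather than a limit, which keeps this pair readable, whereas the remaining compounds offer only a limit of the assay: the limit of > 100000 nM in this assay, at which 2 of the 4 values shown sit.

Still open, going by these compounds, is whether any group at this place can shift the number beyond the scatter, for example an amine, a carboxylic acid, a chlorine atom or a longer alkyl chain on the same aromatic carbon. Also open, on these data alone, is how the other parts of the shared core contribute, as compound 2 and compound 3 each differ from compound 1 in more than one place and so provide no single-change comparison with it.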